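The source may report more compounds than this note shows. Statements on the series, on what has been measured and on what is new or still open speak of the compounds shown alone.

Measured compounds:
compound 1, `NC(=O)[C@@H]1CCCN1C(=O)CCCCCN1CCN(c2cccc(Cl)c2)CC1`: in an assay on HEK293 cells for displacement of a labelled ligand from 5-hydroxytryptamine receptor 7 (Homo sapiens), with a stated time of 1 h (on this read-out higher numbers stand for weaker inhibition and lower numbers for stronger inhibition), compound 1 gives 478 nM
compound 2, `NC(=O)[C@@H]1CCCN1C(=O)CCCCCN1CCN(c2ccc(F)cc2)CC1`: in this assay compound 2 gives 1190 nM

Of the two numbers, compound 2 stands highest, so its displacement is the weaker of the pair; the only other measured compound, compound 1, lies a clear step lower, shown by a 2.5-fold higher number from compound 1 to compound 2 (0.40 log units; beyond the scatter), which arose when 4-fluorophenyl took the place of 3-chlorophenyl on the ring nitrogen.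

Compound 3, `NC(=O)[C@@H]1CCCN1C(=O)CCCCCN1CCN(c2cccc(Cl)c2Cl)CC1`, has not yet been measured in this assay. The change from compound 2 is 2,3-dichlorophenyl in place of 4-fluorophenyl on an amine nitrogen in a ring. Going by the values given here, the one measured step bears on it in two ways: it shows that a phenyl ring carrying chlorine gave a lower number than one carrying fluorine, and it gives a size for such a swap. Going by these compounds, nothing measured here speaks to a second chlorine on the same ring, so that part of the change stays open. On balance a modest move toward lower numbers is expected, roughly a 3.4-fold lower number from compound 2 to compound 3 (0.53 log units; beyond the scatter). For compound 3 the expected value in this assay is 350 nM, within a range from 120 nM to 1000 nM.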

Compound 3, inhibition constant: 179 nM
The estimate for compound 3 lay 2.0-fold (0.29 log units) above the measured number, within the range that was stated.
By their numbers in this assay, from the lowest: compound 3; then compound 1; then compound 2.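

In this assay, chloro in place of hydrogen on an aromatic carbon gave a 2.7-fold lower number from compound 1 to compound 3 (0.43 log units; beyond the scatter), which shows that this phenyl ring on the ring nitrogen can carry a second chlorine and that the number still moves beyond the scatter. Going by these compounds alone, the earlier pair held only one halogen on each ring, whereas the full swap to 2,3-dichlorophenyl now gives a 6.6-fold lower number from compound 2 to compound 3 (0.82 log units; beyond the scatter) and leaves compound 3 with the lowest number of the three, with both of its steps beyond the scatter. Nothing measured here explains why these changes lower the number.

The compounds shown leave open whether the gain depends on having both chlorines in these places on the phenyl ring, or whether a single chlorine at the other position, a methoxy group or a trifluoromethyl group would serve as well. They also leave open how the number would respond to a shorter or longer chain in the shared core, or to a carboxylic acid in place of the terminal amide.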